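A few compounds are considered here, and "the series" means these few. Any claim that something is new, unique, unknown or untested is made for them only; others in the source may bear on it.

Measured in a functional assay on MGC-803 cells (Homo sapiens) for cytotoxicity, read by MTT assay, with a stated time of 72 h; on this read-out lower numbers stand for stronger inhibition and higher numbers for weaker inhibition:
Compound 1 `O=C1C(=Cc2ccc(Cl)cc2)C(=O)N(c2ccc(Cl)cc2)N1c1ccc(Cl)cc1`: 32600 nM
Compound 2 `COc1cc(C=C2C(=O)N(c3ccc(Cl)cc3)N(c3ccc(Cl)cc3)C2=O)ccc1O`: 21800 nM
Compound 3 `O=C1C(=Cc2ccc(F)cc2F)C(=O)N(c2ccc(Cl)cc2)N1c1ccc(Cl)cc1`: 35700 nM

Compound 3 sits together with the other two compounds in this assay. Both of its steps, a 1.1-fold higher number from compound 1 to compound 3 (0.04 log units; within the scatter) and a 1.6-fold higher number from compound 2 to compound 3 (0.21 log units; within the scatter), lie within the scatter. The next compound, compound 4 `O=C1C(=Cc2ccccc2)C(=O)N(c2ccc(Cl)cc2)N1c1ccc(Cl)cc1`, keeps the shared core and carries phenyl in place of 2,4-difluorophenyl on a double-bonded chain carbon bound to a double-bonded ring carbon.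

All three measured steps changed the group at this same place. Besides the two above, there is a 1.5-fold lower number from compound 1 to compound 2 (0.17 log units; within the scatter), also within the scatter. None of these compounds carries phenyl itself, so the evidence is indirect. Still, exchanging 4-chlorophenyl, 4-hydroxy-3-methoxyphenyl and 2,4-difluorophenyl produced no step beyond the scatter, so none is expected here either. The expected 1.2-fold lower number from compound 3 to compound 4 (0.08 log units; within the scatter) therefore stays within the scatter, with no firm direction. For compound 4 the estimated value is 30000 nM, with an expected range from 15000 nM to 60000 nM.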

Compound 4, half-maximal inhibitory concentration: 27200 nM
Compound 4: the middle estimate sits 1.1-fold (0.04 log units) above what was measured, and the stated range covers the measured number.
By their numbers in this assay, from the lowest: compounds 2, 4, 1 and 3 (each within the scatter of the next).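

In this assay the group on a double-bonded chain carbon bound to a double-bonded ring carbon now also appears as phenyl itself, and a 1.3-fold lower number from compound 3 to compound 4 (0.12 log units; within the scatter) joins a 1.2-fold higher number from compound 2 to compound 4 (0.10 log units; within the scatter) as a further step within the scatter. The simplest change in the series, hydrogen in place of chloro on an aromatic carbon, gives a 1.2-fold lower number from compound 1 to compound 4 (0.08 log units; within the scatter) and so also stays within the scatter, which shows that across these four compounds this place tolerates even the bare phenyl without a step beyond the scatter. Nothing available explains why the numbers stay this close.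

The compounds shown leave open whether an amine or a carboxylic acid on this phenyl, or a longer chain in its place, would give a step beyond the scatter. They also leave open whether any change elsewhere on the shared core would do so.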